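Swapping the aryl group on the shared core

The source may hold more compounds than are shown below. What is called first, only, known or untested is meant among the compounds shown, and "the series" means these compounds.

Of the compounds shown here, two with a shared core have been measured in a functional assay on PPC-1 cells (Homo sapiens) for antiproliferative activity, read by sulforhodamine B assay; a higher number here means a weaker inhibitor, a lower number a stronger inhibitor. Compound 1 `CCCCCCCCCCCCCCCCCCNC(=O)[C@H]1CSC(Cc2ccccc2)N1` gives 4000 nM in this assay. Compound 2 `CCCCCCCCCCCCCCCCCCNC(=O)[C@H]1CSC(c2ccc(N(C)C)cc2)N1` gives 1100 nM, which is the lowest of the two numbers, and the step of a 3.6-fold lower number from compound 1 to compound 2 (0.56 log units; beyond the scatter) shows that the aryl group on the saturated ring carbon matters beyond the scatter.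

Compound 3 `CCCCCCCCCCCCCCCCCCNC(=O)[C@H]1CSC(c2cccc(O)c2)N1` differs from compound 2 in just that position: 3-hydroxyphenyl in place of 4-(dimethylamino)phenyl on a saturated ring carbon. Within the data shown here, no measured step exchanges one aryl group for another of this kind, so the only guide is that a change at this position already moved the number by a modest amount between compound 1 and compound 2. The new group carries a hydrogen-bond donor that the leaving group lacks, and the data give no way to tell which direction such a change would take.

On that basis a modest step in either direction, or none beyond the scatter, is expected; compound 3 is estimated at 2200 nM, with a range from 700 nM to 7000 nM, which would mean an expected step of a 2.0-fold higher number from compound 2 to compound 3 (0.30 log units; within the scatter).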

Compound 3, half-maximal inhibitory concentration: 1200 nM
Estimate against measurement, compound 3: 1.8-fold (0.26 log units) above, within the range that was stated.
By their numbers in this assay, from the lowest: compounds 2 and 3 (each within the scatter of the next); then compound 1.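

Exchanging 4-(dimethylamino)phenyl for 3-hydroxyphenyl gives a 1.1-fold higher number from compound 2 to compound 3 (0.04 log units; within the scatter) in this assay, so this assay does not separate these two substituted aromatic rings, even though only the entering group carries a hydrogen-bond donor. Benzyl now stands apart from both: 3-hydroxyphenyl in its place gives a 3.3-fold lower number from compound 1 to compound 3 (0.52 log units; beyond the scatter), making this the second group, after 4-(dimethylamino)phenyl, to give a lower number than benzyl on this saturated ring carbon, and none of the three compounds goes against that pattern. No measurement is available to explain either observation.

Compounds 2 and 3 differ from compound 1 both in lacking the carbon link of benzyl and in carrying a group on the aromatic ring, so the compounds shown cannot say which of these two differences accounts for the step from benzyl. A plain phenyl group at this position would help to separate them, while a carboxylic acid or a primary amine on the aromatic ring would test how far the agreement between compound 2 and compound 3 extends.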